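Working notes: ring exchange on the ring nitrogen, compound 4 pending

This account rests on a few compounds, and the source may have more. Where it says the series, first, only, none or still open, it means among the compounds named here.

Measured so far in a functional assay on HCT-116 cells (Homo sapiens) for cytotoxicity, read by MTT assay, with a stated time of 24 h; on this read-out higher numbers stand for weaker inhibition and lower numbers for stronger inhibition:
Compound 1, `COc1ccc(/C=C\C(=O)O)c(OCc2cn(-c3ccccc3C(=O)N3CCC(O)C3)nn2)c1CC=C(C)C`: 32000 nM
Compound 2, `COc1ccc(/C=C\C(=O)O)c(OCc2cn(-c3ccccc3I)nn2)c1CC=C(C)C`: 23100 nM
Compound 3, `COc1ccccc1-n1cc(COc2c(/C=C\C(=O)O)ccc(OC)c2CC=C(C)C)nn1`: 32200 nM

Compound 3 is not separated from either neighbour in this assay: a 1.0-fold higher number from compound 1 to compound 3 (0.00 log units; within the scatter) and a 1.4-fold higher number from compound 2 to compound 3 (0.14 log units; within the scatter). The third pair behaves the same way, a 1.4-fold lower number from compound 1 to compound 2 (0.14 log units; within the scatter). Across these three compounds, exchanging the group on an aromatic carbon of the ring that sits on the ring nitrogen has left the read-out flat.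

The next compound is compound 4, `COc1ccc(/C=C\C(=O)O)c(OCc2cn(-c3cccnc3Cl)nn2)c1CC=C(C)C`. Its change from compound 3 is 2-chloropyridin-3-yl in place of 2-methoxyphenyl on an aromatic nitrogen. This goes one step further than the measured steps: the whole ring attached to the ring nitrogen is exchanged, not only a group on it. Among the compounds with values here, no measured pair tests such an exchange directly, so the bearing of the three steps is indirect. They do show that this part of the molecule has so far tolerated variation without any step beyond the scatter, and nothing in the data points to a direction.

The expectation for compound 4 is therefore a flat step, a 1.1-fold lower number from compound 3 to compound 4 (0.03 log units; within the scatter). The estimated value for compound 4 in this assay is 30000 nM, with a range from 15000 nM to 60000 nM.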

Compound 4, half-maximal inhibitory concentration: 23000 nM
Estimate against measurement, compound 4: 1.3-fold (0.12 log units) above; measured number inside the range.
By their numbers in this assay, from the lowest: compounds 4, 2, 1 and 3 (each within the scatter of the next).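

Replacing the whole ring on the ring nitrogen does not separate compound 4 from its neighbours in this assay (a 1.4-fold lower number from compound 3 to compound 4 (0.15 log units; within the scatter)), and the comparison with the 2-iodophenyl analogue gives the same picture (a 1.0-fold lower number from compound 2 to compound 4 (0.00 log units; within the scatter)). Earlier steps varied only a group on a six-membered aromatic ring of carbon only, whereas this change brings in 2-chloropyridin-3-yl, a six-membered aromatic ring with a hetero atom, and the read-out stays flat, so tolerance at this position now extends to the ring itself among the compounds shown. No supporting measurement bears on why this exchange leaves the number flat.

The compounds shown keep an aromatic ring on the ring nitrogen, so it remains open whether a saturated ring such as cyclohexyl, or an amine on the aromatic ring, would give a step beyond the scatter. The rest of the shared core is also constant in all of them, which leaves open how a longer chain in place of its alkenyl side chain, or an amide in place of its carboxylic acid, would read out in this assay.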